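The source may hold more compounds than are shown below. What is called first, only, known or untested is meant among the compounds shown, and "the series" means these compounds.

Measured compounds:
- compound 1, `Cc1oc(-c2c(C)c(C)c(C)c(C)c2C)nc1CN1CCC(C(=O)NCCCN2C[C@H](C)C[C@H](C)C2)CC1`: 455 10^-6 cm/s
- compound 2, `Cc1ccccc1-c1nc(CN2CCC(C(=O)NCCCN3[C@H](C)CCC[C@@H]3C)CC2)c(C)o1`: 55.4 10^-6 cm/s
- compound 3, `CCCN(CCC)CCNC(=O)C1CCN(Cc2nc(-c3ccccc3C)oc2C)CC1`: 913 10^-6 cm/s

In a physicochemical assay for permeability, using PAMPA (a lower number here means that the compound crosses the layer more slowly, a higher number that the compound crosses the layer faster), compound 1 stands second highest of the three numbers. Its nearest neighbour is compound 3, whose value of 913 10^-6 cm/s lies within the scatter of that of compound 1. Compound 2, with 55.4 10^-6 cm/s, lies well below compound 1, beyond the scatter. Among the compounds with values here, the only step between compounds differing in one place is a 16-fold higher number from compound 2 to compound 3 (1.22 log units; beyond the scatter), which concerns the amine end of the chain, not the aryl group.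

Compound 4, `Cc1cc(C)cc(-c2nc(CN3CCC(C(=O)NCCCN4C[C@H](C)C[C@H](C)C4)CC3)c(C)o2)c1`, is not yet measured in this assay. It differs from compound 1 as follows: 3,5-dimethylphenyl in place of 2,3,4,5,6-pentamethylphenyl on an aromatic carbon. Within the data shown here, no measured step touches this part of the molecule; compound 1 and compound 2 differ in two places, so their gap cannot be assigned to the aryl change alone. With nothing to go on for this position, a step of a 1.2-fold lower number from compound 1 to compound 4 (0.08 log units; within the scatter) is expected, that is, no clear movement beyond the scatter. Compound 4 is therefore estimated at 380 10^-6 cm/s, with a range from 150 10^-6 cm/s to 800 10^-6 cm/s.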

Compound 4, apparent permeability: 864 10^-6 cm/s
For compound 4 the middle estimate is 2.3-fold (0.36 log units) below the measured one; measured number above the stated range.
By their numbers in this assay, from the lowest: compound 2; then compounds 1, 4 and 3 (each within the scatter of the next).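

First measured step at this position: in this assay, 3,5-dimethylphenyl in place of 2,3,4,5,6-pentamethylphenyl, on an aromatic carbon next to the ring nitrogen and the ring oxygen, gives a 1.9-fold higher number from compound 1 to compound 4 (0.28 log units; within the scatter). Within the data shown here, this change of aryl group therefore does not separate the two compounds, whereas the one step beyond the scatter so far remains the amine-end change, a 16-fold higher number from compound 2 to compound 3 (1.22 log units; beyond the scatter). No supporting data bear on this result.

Open, going by these compounds, is whether an unsubstituted phenyl or a pyridine ring at this position would also stay within the scatter of compound 1. Also open, on these data alone, is how 2-methylphenyl compares with 3,5-dimethylphenyl on an identical amine end, since compound 2 and compound 4 differ in two places.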